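The compounds below may be only part of what the source reports. "The series", "measured", "known", "first", "only" and "open" are said of these compounds alone.

Compound 1 `CC(C)(C)c1cc(/C=C/C(=O)NC2CCN(Cc3ccccc3)CC2)cc(C(C)(C)C)c1O` and compound 2 `COc1ccc(CN2CCC(CCNC(=O)/C=C/c3cc(C(C)(C)C)c(O)c(C(C)(C)C)c3)CC2)cc1` share one core and differ only in the chain and the benzyl substituent. In an assay on isolated protein for inhibition of Amine oxidase [flavin-containing] A (Homo sapiens), read by fluorescence, with stated times of 15 min and 20 min (a higher number here means a weaker inhibitor, a lower number a stronger inhibitor), compound 1 gives 42500 nM. In this assay, among the measured compounds shown here, compound 2 gives 72500 nM, a number within the usual scatter of the one for compound 1, so the two compounds cannot be told apart on these data. Compound 3 `CC(C)(C)c1cc(/C=C/C(=O)NCCC2CCN(Cc3ccc(F)cc3)CC2)cc(C(C)(C)C)c1O` has not been measured in this assay. It differs from compound 2 by fluoro in place of methoxy on an aromatic carbon. For the measured compounds named here, no measured pair shows this change, so the step of a 1.0-fold lower number from compound 2 to compound 3 (0.02 log units; within the scatter) is expected to stay within the scatter. Compound 3 is estimated at 70000 nM, between 25000 nM and 200000 nM.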

Compound 3, half-maximal inhibitory concentration: 59600 nM
Beside the measured number, compound 3's estimate is 1.2-fold (0.07 log units) above it; the range from low to high includes it.
By their numbers in this assay, from the lowest: compounds 1, 3 and 2 (each within the scatter of the next).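

In this assay the change from 4-methoxybenzyl to 4-fluorobenzyl gives a 1.2-fold lower number from compound 2 to compound 3 (0.09 log units; within the scatter) and forms the first pair shown that differs in only one place. At this position on the aromatic ring, methoxy and fluoro therefore cannot be told apart, although both numbers stay high. No measurement shown gives a reason for this result.

Still open, from the compounds shown here alone, is whether an amine or a carboxylic acid at this position would give a number beyond the scatter. Going by these compounds, it is also open whether a plain hydrogen there would read the same.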